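Propyl to Isopropyl on Two Unmeasured Cores

The source may report more compounds than this note shows. Statements on the series, on what has been measured and on what is new or still open speak of the compounds shown alone.

Compound 1, `Cc1nc(C(C)C)n2c(O)nnc(-c3ccccc3)c12`, in a functional assay for inhibition, with Homo sapiens as the target (on this read-out lower numbers stand for stronger inhibition and higher numbers for weaker inhibition), gives > 48000 nM, which is a limit of the assay.
Compound 2, `CCCc1nc(C)c2c(-c3ccccc3)nnc(O)n12`, in this assay gives > 48000 nM, also a limit.
Compound 3, `CCCc1nnc(SC)n2c(CCC)nc(C)c12`, in this assay gives > 48000 nM, again a limit.

Every measured value sits at the limit of > 48000 nM in this assay, at which 3 of the 3 values shown sit. The change from compound 2 to compound 1 is isopropyl in place of propyl on an aromatic carbon, and its step is a step that the two limits leave unreadable from compound 2 to compound 1. Compound 4, `CCCc1nc(C)c2c(C(C)C)nnc(SC)n12`, is not yet measured; it arises from compound 3 through (isopropyl in place of propyl on an aromatic carbon). This is the same kind of change, not the same: in compound 1 it lies on a five-membered aromatic ring with 2 nitrogen, between two ring nitrogen atoms, whereas in compound 4 it lies on a six-membered aromatic ring with 3 nitrogen, next to the ring nitrogen, para to a methylsulfanyl group. The difference between the cores of compound 2 and compound 3 is not broken down here. Because compound 3 sits at the limit of > 48000 nM in this assay, at which 3 of the 3 values shown sit, the step from compound 3 to compound 4 is expected to be a step that the limit leaves unreadable from compound 3 to compound 4. Compound 4 is therefore estimated at 80000 nM, most likely again only a limit, within 20000 nM to 400000 nM.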

Compound 4, half-maximal inhibitory concentration: > 48000 nM
Compound 4 ended at the assay's limit; the forecaster's own chance of this, stated with the estimate: 85%; the middle value lies beyond the limit too.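

Going by these compounds alone, compound 3 and compound 4 both stop at a limit in this assay rather than at a number, so no step between them can be read: the limit of > 48000 nM in this assay, at which 4 of the 4 values shown sit. The compounds shown leave open how strongly any of them inhibits, and whether swapping propyl for isopropyl changes that at all.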